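This account rests on a few compounds, and the source may have more. Where it says the series, first, only, none or still open, it means among the compounds named here.

Notes on the series. For the measured compounds named here, compound 1 `CC(C)(C)n1cc2c(n1)C(=O)CC1(CCN(C(=O)c3cc(-c4ccccc4Cl)nc4ccccc34)CC1)O2` sits in the middle of the three numbers so far: in a functional assay on A549 cells (Homo sapiens) for inhibition, read by MTT assay, with a stated time of 72 h (a lower number here means a stronger inhibitor, a higher number a weaker inhibitor), compound 1 gives 2180 nM, the second highest of the three. Compound 2 `COc1ccc(-c2cc(C(=O)N3CCC4(CC3)CC(=O)c3nn(C(C)(C)C)cc3O4)c3ccccc3n2)cc1` gives 3740 nM, and compound 3 `CC(C)(C)n1cc2c(n1)C(=O)CC1(CCN(C(=O)c3cc(-c4ccncc4)nc4ccccc34)CC1)O2` gives 550 nM. The step of a 1.7-fold higher number from compound 1 to compound 2 (0.23 log units; within the scatter) stays within the scatter, whereas a 4.0-fold lower number from compound 1 to compound 3 (0.60 log units; beyond the scatter) and a 6.8-fold lower number from compound 2 to compound 3 (0.83 log units; beyond the scatter) lie beyond it. Compound 4 `CC(C)(C)n1cc2c(n1)C(=O)CC1(CCN(C(=O)c3cc(N4CCNCC4)nc4ccccc34)CC1)O2` differs from compound 1 as follows: piperazin-1-yl in place of 2-chlorophenyl on an aromatic carbon. Going by the values given here, no measured step exchanges the aromatic ring for a non-aromatic one, so the two steps from compound 1 are only a loose guide, and a step beyond the scatter cannot be expected in either direction with confidence. Compound 4 is therefore estimated at 1500 nM, with a range of 300 nM to 8000 nM, which means an expected step of a 1.5-fold lower number from compound 1 to compound 4 (0.16 log units; within the scatter).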

Compound 4, half-maximal inhibitory concentration: > 10000 nM
Compound 4 gave a limit, no number; the forecaster's own chance of this, stated with the estimate: 10%; middle value at least 6.6-fold (0.82 log units) away from the limit.
By their numbers in this assay, from the lowest: compound 3; then compounds 1 and 2 (each within the scatter of the next). At a limit, above all of these: compound 4.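

Compound 4 gives only a limit, not a number, in this assay: the limit of > 10000 nM in this assay, at which 1 of the 4 values shown sits. Piperazin-1-yl at this aromatic carbon brings an at least 4.5-fold higher number from compound 1 to compound 4 (0.66 log units; beyond the scatter) and an at least 2.6-fold higher number from compound 2 to compound 4 (0.42 log units; beyond the scatter) and also an at least 18-fold higher number from compound 3 to compound 4 (1.25 log units; beyond the scatter) in each case beyond the scatter. Among the four compounds, the three with an aromatic ring here give numbers, whereas the one with a non-aromatic ring gives only a limit.

The compounds shown do not separate the absence of an aromatic ring from the presence of the secondary ring amine. Morpholin-4-yl or 4-methylpiperazin-1-yl at this position would bear on that question.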